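This account rests on a few compounds, and the source may have more. Where it says the series, first, only, none or still open, it means among the compounds named here.

Of the compounds shown here, three that share one core have been tested in an assay on T-REx-293 cells for inhibition of potassium channel subfamily T member 1 (Homo sapiens), read by patch clamp; a higher number here means a weaker inhibitor, a lower number a stronger inhibitor. Compound 1 `Cc1ccnc(-c2noc([C@H](C)NC(=O)c3cc(C(F)(F)F)nn3C)n2)c1` gives 4470 nM in this assay. Compound 2 `C[C@H](NC(=O)c1cc(C(F)(F)F)nn1C)c1nc(-c2ccncc2)no1` gives 5250 nM in this assay. Compound 3 `C[C@H](NC(=O)c1cc(C(F)(F)F)nn1C)c1nc(-c2cccnc2)no1` gives 11800 nM in this assay, the highest of the three numbers, so it is the weakest inhibitor among them: the step of a 2.6-fold higher number from compound 1 to compound 3 (0.42 log units; beyond the scatter) and the step of a 2.2-fold higher number from compound 2 to compound 3 (0.35 log units; beyond the scatter) both lie beyond the scatter, whereas the step of a 1.2-fold higher number from compound 1 to compound 2 (0.07 log units; within the scatter) lies within it.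

Compound 4 `C[C@H](NC(=O)c1cc(C(F)(F)F)nn1C)c1nc(-c2cnn(C)c2)no1` differs from compound 3 in one place: 1-methyl-1H-pyrazol-4-yl in place of pyridin-3-yl on an aromatic carbon. The measured steps that bear on this are the two in which pyridin-3-yl entered, namely a 2.6-fold higher number from compound 1 to compound 3 (0.42 log units; beyond the scatter) and a 2.2-fold higher number from compound 2 to compound 3 (0.35 log units; beyond the scatter), both modest increases. Here pyridin-3-yl leaves again, but the group that enters appears in no measured compound, so no step shows what it does on its own. Because the steps of a 2.6-fold higher number from compound 1 to compound 3 (0.42 log units; beyond the scatter) and a 2.2-fold higher number from compound 2 to compound 3 (0.35 log units; beyond the scatter) raised the number when pyridin-3-yl came in, its removal is expected to lower the number a little, so the expected step is a 1.7-fold lower number from compound 3 to compound 4 (0.23 log units; within the scatter), which stays within the scatter. The estimate for compound 4 in this assay is 7000 nM, with a range from 2500 nM to 20000 nM.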

Compound 4, half-maximal inhibitory concentration: 2640 nM
Compound 4: the middle estimate sits 2.7-fold (0.42 log units) above what was measured; the range from low to high includes it.
By their numbers in this assay, from the lowest: compounds 4, 1 and 2 (each within the scatter of the next); then compound 3.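

In this assay, this position on the shared core is not limited to six-membered aromatic rings: putting 1-methyl-1H-pyrazol-4-yl, a five-membered aromatic ring with 2 hetero atoms, in place of pyridin-3-yl gives a 4.5-fold lower number from compound 3 to compound 4 (0.65 log units; beyond the scatter). Set against the other two pyridine groups, the same group gives a 2.0-fold lower number from compound 2 to compound 4 (0.30 log units; within the scatter) and a 1.7-fold lower number from compound 1 to compound 4 (0.23 log units; within the scatter), so compounds 1, 2 and 4 form one level within the scatter, with compound 3 alone standing apart as the weaker inhibitor, and a six-membered ring is not needed to reach that level. Nothing measured here explains why the pyridin-3-yl compound stands apart from the other three.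

Every group shown at this position is an aromatic ring containing nitrogen, so it remains open whether a plain phenyl ring, with no ring nitrogen, or a saturated ring such as morpholine would keep the same level. As far as these compounds go, it is also open what the methyl on the pyrazole contributes, which a comparison with the unsubstituted 1H-pyrazol-4-yl group or with a longer chain such as ethyl on that ring nitrogen would show.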